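The compounds below may be only part of what the source reports. "The series", "measured", "known", "first", "only" and "open" are said of these compounds alone.

Measured compounds:
compound 1, `C=CCN(Cc1ccc2nc(C)[nH]c(=O)c2c1)c1ccc(C(=O)N[C@@H](CCC(=O)O)C(=O)O)cc1`, 170 nM;
compound 2, `CCN(Cc1ccc2nc(C)[nH]c(=O)c2c1)c1ccc(C(=O)N[C@@H](CCC(=O)O)C(=O)O)c(C)c1`, 1200 nM;
compound 3, `C=CCN(Cc1ccc2nc(C)[nH]c(=O)c2c1)c1ccc(C(=O)N[C@@H](CCC(=O)O)C(=O)O)c(F)c1`, 100 nM.

In a functional assay on L1210 cells (Mus musculus) for inhibition (a higher number here means a weaker inhibitor, a lower number a stronger inhibitor), compound 2 gives the highest of the three numbers. Its nearest neighbour is compound 1 with 170 nM, and the furthest is compound 3 with 100 nM; both gaps lie beyond the scatter. Compound 2 differs from compound 1 in more than one place, so the numbers of those two speak only for themselves.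

The unmeasured compound 4, `CCN(Cc1ccc2nc(C)[nH]c(=O)c2c1)c1ccc(C(=O)N[C@@H](CCC(=O)O)C(=O)O)c(Cl)c1`, follows from compound 2 by a single change: chloro in place of methyl on an aromatic carbon.

Within the data shown here, only one measured step concerns a halogen entering this aromatic ring: a 1.7-fold lower number from compound 1 to compound 3 (0.23 log units; within the scatter). That step swaps a hydrogen for a fluoro and stays within the scatter, so it gives at best a faint pointer toward a lower number when a halogen sits at this position. Among the measured compounds shown here, no measured pair shows chloro in place of methyl, so the size of the step for compound 4 is uncertain. The account therefore expects compound 4 to land somewhat below compound 2, with the step of a 2.0-fold lower number from compound 2 to compound 4 (0.30 log units; within the scatter) as the expected change. The estimate for compound 4 in this assay is 600 nM, within a range from 200 nM to 1800 nM.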

Compound 4, half-maximal inhibitory concentration: 870 nM
The estimate for compound 4 lay 1.5-fold (0.16 log units) below the measured number, and the stated range covers the measured number.
By their numbers in this assay, from the lowest: compounds 3 and 1 (each within the scatter of the next); then compounds 4 and 2 (each within the scatter of the next).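

In this assay, chloro in place of methyl, on an aromatic carbon ortho to a large group and meta to a large group, gives a 1.4-fold lower number from compound 2 to compound 4 (0.14 log units; within the scatter), so this read-out does not separate these two groups at this position. Among these compounds, until now, the only single change at this carbon was hydrogen to fluoro, a 1.7-fold lower number from compound 1 to compound 3 (0.23 log units; within the scatter), on the compounds carrying the allyl group; the new step adds a second single change at the same carbon, this time on the compounds carrying the ethyl group, and it too stays within the scatter. Nothing measured on these compounds offers an explanation for this result.

From the compounds shown here alone, it remains open how a methoxy group, an amine or a nitrile at this aromatic carbon would read, and how a plain hydrogen there would read with the ethyl group on the shared core. Going by these compounds, the part played by ethyl against allyl also stays open, as every compound with one differs from every compound with the other in a second place as well.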